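This account rests on a few compounds, and the source may have more. Where it says the series, first, only, none or still open, it means among the compounds named here.

Measured so far:
compound 1 `CCN(Cc1cccc(Br)c1)c1ccc(C(=O)N2CCc3ccc(OS(N)(=O)=O)cc3C2)cc1` gives 1.93 in a physicochemical assay for lipophilicity; a higher number here means a more lipophilic compound, a lower number a more polar compound
compound 2 `CN(C)CCN(CCN(C)C)c1ccc(C(=O)N2CCc3ccc(OS(N)(=O)=O)cc3C2)cc1` gives 1.93 in this assay
compound 3 `CN(C)CCCN(Cc1ccccc1)c1ccc(C(=O)N2CCc3ccc(OS(N)(=O)=O)cc3C2)cc1` gives 1.93 in this assay

All three share the same core and differ only in the groups carried on a nitrogen on an aromatic ring. On the numbers shown, compound 3 stands level with compound 1 and with compound 2: the gap to compound 1 and the gap to compound 2 both lie within the scatter of this assay, so nothing separates the three compounds.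

The unmeasured compound 4 `NS(=O)(=O)Oc1ccc2c(c1)CN(C(=O)c1ccc(N(Cc3ccccc3)Cc3ccco3)cc1)CC2` is reached from compound 3 by a single exchange: furan-2-yl in place of 2-(dimethylamino)ethyl on a saturated chain carbon bound to a nitrogen on an aromatic ring. Going by the values given here, only one measured step touches the same part of the molecule, no change at the digits printed from compound 1 to compound 2 (within the scatter). There, a different pair of groups on that nitrogen was swapped for another and the value did not move beyond the scatter. The change to compound 4 is of the same kind, an exchange of groups on the nitrogen on the aromatic ring, and it is expected to behave the same way, with no step beyond the scatter, no change at the digits printed from compound 3 to compound 4 (within the scatter). Compound 4 is therefore estimated at 1.93 in this assay, expected to fall between 1.5 and 2.5.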

Compound 4, partition coefficient: 1.93
Estimate against measurement, compound 4: no gap at the digits printed, and the stated range covers the measured number.
By their numbers in this assay, from the lowest: compounds 1, 2, 3 and 4 (each within the scatter of the next).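

In this assay, the new exchange reads no change at the digits printed from compound 3 to compound 4 (within the scatter). This step shows something the earlier one could not: no change at the digits printed from compound 1 to compound 2 (within the scatter) replaced both groups on the nitrogen on the aromatic ring at once, whereas here one group changes and the other stays in place, so a single group can be read alone. The two groups exchanged, 2-(dimethylamino)ethyl and furan-2-yl, each have 5 heavy atoms but are otherwise unlike, as an open chain with a nitrogen gives way to a five-membered aromatic ring with an oxygen, and even this swap stays within the scatter; nothing shown accounts for that result.

The compounds shown leave open whether a carboxylic acid at the end of the chain, or a much longer chain of plain carbons, would also leave the reading of this assay within the scatter. Every step shown also sits on this one nitrogen, so what an exchange elsewhere on the shared core would do remains an open question.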